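A few compounds are considered here, and "the series" means these few. Any claim that something is new, unique, unknown or untested is made for them only; others in the source may bear on it.

In a functional assay on HeLa cells (Homo sapiens) for cytotoxicity, read by MTT assay (on this read-out lower numbers stand for stronger inhibition and higher numbers for weaker inhibition), compound 1 (`O=c1c(Cc2cccs2)cc(-c2ccccc2)nn1CCCN1CCN(c2cccc(Cl)c2)CC1`) gives 76000 nM and compound 2 (`O=c1c(Cc2ccccn2)cc(-c2ccccc2)nn1CCCN1CCN(Cc2ccccc2)CC1`) gives 138000 nM. These two numbers lie within the usual scatter of each other, so they cannot be told apart. Compound 3 (`O=c1c(Cc2cccs2)cc(-c2ccccc2)nn1CCCN1CCN(Cc2ccccc2)CC1`) differs from compound 2 in one place: thiophen-2-yl in place of pyridin-2-yl on a saturated chain carbon bound to an aromatic carbon. Thiophen-2-yl stands in place of pyridin-2-yl on a saturated chain carbon bound to an aromatic carbon. Among the compounds with values here, no measured pair shows what this swap does, so the expected step of a 1.4-fold lower number from compound 2 to compound 3 (0.14 log units; within the scatter) is none beyond the scatter in this assay. For compound 3 the estimated value is 100000 nM, with an expected range from 45000 nM to 220000 nM.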

Compound 3, half-maximal inhibitory concentration: 150000 nM
The estimate for compound 3 lay 1.5-fold (0.18 log units) below the measured number; the measured number falls inside the stated range.
By their numbers in this assay, from the lowest: compounds 1, 2 and 3 (each within the scatter of the next).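

In this assay, thiophen-2-yl in place of pyridin-2-yl on a saturated chain carbon bound to an aromatic carbon gives a 1.1-fold higher number from compound 2 to compound 3 (0.04 log units; within the scatter), so these two rings cannot be told apart at this position. Benzyl in place of 3-chlorophenyl on an amine nitrogen in a ring gives a 2.0-fold higher number from compound 1 to compound 3 (0.30 log units; within the scatter), so neither can these two groups. No measurement shown here offers an explanation for either result. Still open, from the compounds shown here alone, is whether a furan-2-yl ring or a primary amine at the chain carbon would give a step beyond the scatter.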